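Replacing the hydroxyethyl pyrazolyl group with phenyl

The compounds below may be only part of what the source reports. "The series", "measured", "known", "first", "only" and "open" are said of these compounds alone.

In a functional assay on NCI-H1993 cells (Homo sapiens) for inhibition, read by CCK-8 assay, with a stated time of 72 h (a higher number here means a weaker inhibitor, a lower number a stronger inhibitor), compound 2 `CC(c1c(F)cc2ncccc2c1F)n1cnc2ncc(-c3cnn(CCO)c3)nc21` gives 83.7 nM, the lowest number among those shown. Compound 1 `CC(c1cc2cccnc2cc1F)n1cnc2ncc(-c3cnn(CCO)c3)nc21` gives 175 nM. Among the compounds with values here, the only measured step, a 2.1-fold lower number from compound 1 to compound 2 (0.32 log units; beyond the scatter), is modest and is fluoro in place of hydrogen, so it does not bear directly on the change at hand. Compound 4 `CC(c1c(F)cc2ncccc2c1F)n1cnc2ncc(-c3ccccc3)nc21` has phenyl in place of 1-(2-hydroxyethyl)-1H-pyrazol-4-yl on an aromatic carbon. Compound 3 `CC(c1cc(F)c2ncccc2c1)n1cnc2ncc(-c3ccccc3)nc21`, which also carries phenyl but differs in its fluoro substitution, reads > 10000 nM in this assay, a limit of the assay, and this sets the expectation of a much higher number. The expected change is large and upward, a 110-fold higher number from compound 2 to compound 4 (2.03 log units; beyond the scatter). For compound 4 the estimate is 9000 nM, with an expected range of 2000 nM to 40000 nM.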

Compound 4, half-maximal inhibitory concentration: 514 nM
Estimate against measurement, compound 4: 18-fold (1.24 log units) above, and the stated range ends above it.
By their numbers in this assay, from the lowest: compound 2; then compound 1; then compound 4. At a limit, above all of these: compound 3.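

In this assay, within the data shown here, phenyl in place of 1-(2-hydroxyethyl)-1H-pyrazol-4-yl gives a 6.1-fold higher number from compound 2 to compound 4 (0.79 log units; beyond the scatter) and is the first direct reading of this change at this position. Compound 4 still gives a measured number, so phenyl here does not by itself reach the end of the assay range. Compound 3, also carrying phenyl, gives only a limit and not a number: the limit of > 10000 nM in this assay, at which 1 of the 4 values shown sits.

From the compounds shown here alone, whether the loss follows from the hydroxyethyl chain or from the five-membered ring stays open. A 1-(2-aminoethyl)-1H-pyrazol-4-yl group or an unsubstituted pyrazol-4-yl group at this position would separate the two.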